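Halogenated benzyl adenosine series: estimate for the difluoro analogue

The source may hold more compounds than are shown below. What is called first, only, known or untested is meant among the compounds shown, and "the series" means these compounds.

Measured compounds:
compound 1 `OC[C@H]1O[C@@H](n2cnc3c(NCc4ccc(F)cc4)ncnc32)[C@H](O)[C@@H]1O` — 2700 nM
compound 2 `OC[C@H]1O[C@@H](n2cnc3c(NCc4ccc(Cl)cc4)ncnc32)[C@H](O)[C@@H]1O` — 218000 nM
compound 3 `OC[C@H]1O[C@@H](n2cnc3c(NCc4cccc(Br)c4)ncnc32)[C@H](O)[C@@H]1O` — 19700 nM

In a functional assay on K562 cells (Homo sapiens) for antiproliferative activity, with a stated time of 72 h (a lower number here means a stronger inhibitor, a higher number a weaker inhibitor), compound 1 gives the lowest number of the three; compound 3 stands nearest, with a 7.3-fold higher number from compound 1 to compound 3 (0.86 log units; beyond the scatter), and compound 2 furthest, with an 81-fold higher number from compound 1 to compound 2 (1.91 log units; beyond the scatter). Compound 4 `OC[C@H]1O[C@@H](n2cnc3c(NCc4ccc(F)cc4F)ncnc32)[C@H](O)[C@@H]1O` differs from compound 1 by fluoro in place of hydrogen on an aromatic carbon. For the measured compounds named here, no measured step adds a second halogen to the benzyl group, so the bearing of the known steps is indirect: both halogen changes, an 81-fold higher number from compound 1 to compound 2 (1.91 log units; beyond the scatter) and a 7.3-fold higher number from compound 1 to compound 3 (0.86 log units; beyond the scatter), moved the number upward, the first by a large and the second by a modest amount. A further halogen on the same ring is therefore expected to raise the number modestly, with wide uncertainty. Compound 4 is estimated at 5000 nM, range 1200 nM to 25000 nM, meaning an expected 1.9-fold higher number from compound 1 to compound 4 (0.27 log units; within the scatter).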

Compound 4, half-maximal inhibitory concentration: 9600 nM
Compound 4: the middle estimate sits 1.9-fold (0.28 log units) below what was measured; the range from low to high includes it.
By their numbers in this assay, from the lowest: compound 1; then compound 4; then compound 3; then compound 2.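

In this assay, a fluoro ortho to a large group on the 4-fluorobenzyl ring is not a neutral change (a 3.6-fold higher number from compound 1 to compound 4 (0.55 log units; beyond the scatter)). The resulting 2,4-difluorobenzyl compound still keeps a lower number than both single-halogen comparators (a 2.1-fold lower number from compound 3 to compound 4 (0.31 log units; beyond the scatter); a 23-fold lower number from compound 2 to compound 4 (1.36 log units; beyond the scatter)). No measurement on hand accounts for these steps.

Open, from the compounds shown here alone, is whether a chloro, methyl or methoxy group at this position gives a similar rise. Also open, going by these compounds, is whether the same added fluoro would shift the 4-chlorobenzyl compound 2 to a similar extent.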